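The compounds below may be only part of what the source reports. "The series", "measured", "known", "first", "only" and "open" are said of these compounds alone.

Of the compounds shown here, two of a shared core have been tested in a functional assay on SF-295 cells (Homo sapiens) for inhibition, read by sulforhodamine B assay, with a stated time of 48 h; a lower number here means that less compound is tolerated, a higher number that more compound is tolerated. Compound 1 `O=C(Nc1cccc(-n2cc(-c3ccncc3)c(-c3ccc(Cl)c(O)c3)n2)c1)Nc1cccc(C(F)(F)F)c1` gives 29200 nM. Compound 2 `COc1cc(-c2nn(-c3cccc(NC(=O)Nc4ccc(Cl)c(Cl)c4)c3)cc2-c2ccncc2)ccc1Cl` reaches only the limit of the assay, > 50000 nM, so for compound 2 a limit and no number is known. That limit is where compound 2 stands, as shown by the limit of > 50000 nM in this assay, at which 1 of the 2 values shown sits. Compound 3 `COc1cc(-c2nn(-c3cccc(NC(=O)Nc4cccc(C(F)(F)F)c4)c3)cc2-c2ccncc2)ccc1Cl` has not been measured yet. It differs from compound 2 in one place: 3-(trifluoromethyl)phenyl in place of 3,4-dichlorophenyl on an amide-type nitrogen. Among the compounds with values here, no measured pair of compounds shows this change alone, since compound 1 and compound 2 differ in a second place as well. The step from compound 2 to compound 3 is therefore expected to stay small, an at least 1.2-fold lower number from compound 2 to compound 3 (0.09 log units; that floor lies within the scatter), with no direction beyond the scatter. Compound 3 is expected to give about 40000 nM in this assay, somewhere between 18000 nM and 90000 nM, with a real chance that only a limit is reported.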

Compound 3, concentration lethal to 50% of the cells: 3200 nM
For compound 3 the middle estimate is 13-fold (1.10 log units) above the measured one, outside the stated range (below it).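

In this assay, the group on the amide-type nitrogen turns out to matter a great deal: 3-(trifluoromethyl)phenyl in place of 3,4-dichlorophenyl gives an at least 15-fold lower number from compound 2 to compound 3 (1.19 log units; beyond the scatter). Compound 2 has only a limit and no number, so this step is a lower bound on the true size of the change: the limit of > 50000 nM in this assay, at which 1 of the 3 values shown sits. The group on the oxygen on the aromatic ring matters too, since methyl in place of hydrogen, with 3-(trifluoromethyl)phenyl kept, gives a 9.1-fold lower number from compound 1 to compound 3 (0.96 log units; beyond the scatter).

From the compounds shown here alone, whether either step holds with the other group in place stays open, as each change is seen only once. Also open, going by these compounds, is how an amine or a carboxylic acid on that phenyl ring, or a longer chain such as ethyl on the oxygen, would read.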